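Benzyl in place of carbonyl at the ring nitrogen

A few compounds are considered here, and "the series" means these few. Any claim that something is new, unique, unknown or untested is made for them only; others in the source may bear on it.

Compound 2 `O=C(N1CCOCC1)n1cc(-c2ccc3cn[nH]c3c2)ccc1=O` gives in an assay for inhibition of MAP kinase-interacting serine/threonine-protein kinase 1 (Homo sapiens), read by luminescence and ADP-Glo, with a stated time of 2 h (on this read-out higher numbers stand for weaker inhibition and lower numbers for stronger inhibition), only a limit, > 2000 nM. Compound 2 therefore stands at the limit of > 2000 nM in this assay, at which 1 of the 3 values shown sits. Within the data shown here, compound 1 `O=c1ccc(-c2ccc3cn[nH]c3c2)cn1Cc1ccccc1C(F)(F)F` gives 133 nM in this assay and compound 3 `NC(=O)c1ccccc1Cn1cc(-c2ccc3cn[nH]c3c2)ccc1=O` gives 878 nM; the single measured step, a 6.6-fold higher number from compound 1 to compound 3 (0.82 log units; beyond the scatter), shows that the group carried on the benzyl ring shifts the number while both values stay well inside the measurable range. Compound 4 `O=c1ccc(-c2ccc3cn[nH]c3c2)cn1Cc1cccc(F)c1` differs from compound 2 by 3-fluorobenzyl in place of (morpholin-4-yl)carbonyl on an aromatic nitrogen. Among the measured compounds shown here, no measured step covers this exchange directly, but both benzyl compounds 1 and 3 sit well inside the measurable range. Compound 4 is therefore expected near 300 nM, with a range from 100 nM to 900 nM. That estimate means an expected at least 6.6-fold lower number from compound 2 to compound 4 (0.82 log units; beyond the scatter).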

Compound 4, half-maximal inhibitory concentration: 74 nM
For compound 4 the middle estimate is 4.1-fold (0.61 log units) above the measured one; the whole stated range lies above it.
By their numbers in this assay, from the lowest: compounds 4 and 1 (each within the scatter of the next); then compound 3. At a limit, above all of these: compound 2.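

At the aromatic nitrogen, 3-fluorobenzyl in place of (morpholin-4-yl)carbonyl gives an at least 27-fold lower number from compound 2 to compound 4 (1.43 log units; beyond the scatter) in this assay. The value of compound 2 is a limit, so this step is a bound and not an exact size: the limit of > 2000 nM in this assay, at which 1 of the 4 values shown sits. Compound 4 now gives a direct single-place link between the benzyl type of group and a value inside the measurable range, which compounds 1 and 3 could not give.

Open, as far as these compounds go, is whether the carbonyl linker or the morpholine ring drives the step, and how a plain unsubstituted benzyl or a benzyl carrying a carboxylic acid or an amine would read.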